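Benzyl(methyl)amide in place of the tetrahydroisoquinoline amide

This account rests on a few compounds, and the source may have more. Where it says the series, first, only, none or still open, it means among the compounds named here.

Compound 1 `CS(=O)(=O)c1ccc(C(=O)N2CCC(C(=O)N3CCc4ccccc4C3)CC2)cc1[N+](=O)[O-]`: > 60000 nM
Compound 2 `CS(=O)(=O)c1ccc(C(=O)NCCC(=O)N2CCc3ccccc32)cc1[N+](=O)[O-]`: > 60000 nM
Compound 3 `CS(=O)(=O)c1ccc(C(=O)NCCC(=O)N2CCCc3ccccc32)cc1[N+](=O)[O-]`: > 60000 nM

In an assay on isolated protein for inhibition of thyroid hormone receptor beta (Homo sapiens), read by fluorescence polarization (on this read-out lower numbers stand for stronger inhibition and higher numbers for weaker inhibition), compound 1 gives > 60000 nM, which is a limit of the assay rather than a number. Compound 2 likewise gives only a limit, > 60000 nM. Compound 3 also gives a limit, > 60000 nM. Because of the limit of > 60000 nM in this assay, at which 3 of the 3 values shown sit, a step that the two limits leave unreadable from compound 2 to compound 3 cannot be read, and compound 1 stands at the limit alongside the other two. Compound 4 `CN(Cc1ccccc1)C(=O)C1CCN(C(=O)c2ccc(S(C)(=O)=O)c([N+](=O)[O-])c2)CC1` differs from compound 1 by benzyl(methyl)amino in place of 1,2,3,4-tetrahydroisoquinolin-2-yl on a carbonyl carbon. For the measured compounds named here, no measured step bears on this change, and the one step measured is unreadable, so no size or direction beyond the scatter can be expected. Compound 4 is therefore expected to remain at the limit, estimated at 100000 nM (range 30000 nM to 300000 nM). The expected step is a step that the limit leaves unreadable from compound 1 to compound 4.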

Compound 4, half-maximal inhibitory concentration: > 60000 nM
Compound 4 was reported as a limit; the forecaster's own chance of this, stated with the estimate: 85%; the middle value is on the limit's open side.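

No step can be read between compound 1 and compound 4, because both stand at a limit of the assay: the limit of > 60000 nM in this assay, at which 4 of the 4 values shown sit. Which change to the shared core, if any, would give a measurable value in this assay stays open.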